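From a (furan-2-yl)methyl ester to a propyl ester

The source may report more compounds than this note shows. Statements on the series, on what has been measured and on what is new or still open speak of the compounds shown alone.

Compounds measured so far:
Compound 1 `C/C=C1/[C@H](O[C@@H]2O[C@H](CO)[C@@H](O)[C@H](O)[C@H]2O)OC=C(C(=O)OC)[C@H]1CC(=O)OCc1ccco1` in a functional assay on SK-BR-3 cells (Homo sapiens) for antiproliferative activity, read by MTT assay, with a stated time of 72 h (a higher number here means a weaker inhibitor, a lower number a stronger inhibitor), gives > 15000 nM, a limit of the assay.
Compound 2 `C/C=C1/[C@H](O[C@@H]2O[C@H](CO)[C@@H](O)[C@H](O)[C@H]2O)OC=C(C(=O)OC)[C@H]1CC(=O)OCc1ccc2c(c1)OCCO2` gives > 15000 nM, again a limit.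
Compound 3 `C/C=C1/[C@H](O[C@@H]2O[C@H](COC(C)=O)[C@@H](OC(C)=O)[C@H](OC(C)=O)[C@H]2OC(C)=O)OC=C(C(=O)OC)[C@H]1CC(=O)OCCC(C)C` gives > 15000 nM, also a limit.

Compound 1 therefore stands only at a limit, with no number of its own, and the two further values shown are limits as well. Compound 4 `C/C=C1/[C@H](O[C@@H]2O[C@H](CO)[C@@H](O)[C@H](O)[C@H]2O)OC=C(C(=O)OC)[C@H]1CC(=O)OCCC` differs from compound 1 in this way: ethyl in place of furan-2-yl on a saturated chain carbon bound to an oxygen next to a carbonyl group. For the measured compounds named here, the one measured step of a comparable change, a step that the two limits leave unreadable from compound 1 to compound 2, sits between two limits and so has no readable size. Going by the values given here, with the limit of > 15000 nM in this assay, at which 3 of the 3 values shown sit, no measured step gives a size to expect, so compound 4 is expected to stay at the limit, meaning a step that the limit leaves unreadable from compound 1 to compound 4. Compound 4 is therefore estimated at 25000 nM, between 8000 nM and 80000 nM.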

Compound 4, half-maximal inhibitory concentration: > 15000 nM
Compound 4 gave a limit, no number; the forecaster's own chance of this, stated with the estimate: 85%; the middle value lies beyond the limit too.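

Compound 4, like compound 1 and compound 2, stands only at a limit of the assay, so the steps from compound 1 and compound 2 to compound 4 cannot be read. Whether any of the esters shown reaches a measurable value in this assay stays open.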